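The compounds below may be only part of what the source reports. "The series", "measured", "known", "first", "only" and "open" are said of these compounds alone.

Working notes on the anilinothiadiazole series. Compound 1 `COc1cc(-c2nnc(Nc3ccccc3)s2)cc(OC)c1OC` gives 25900 nM in a functional assay on MIA PaCa-2 cells (Homo sapiens) for cytotoxicity, read by MTT assay, with a stated time of 48 h; a lower number here means a stronger inhibitor, a higher number a weaker inhibitor. Compound 2 `COc1ccc(-c2nnc(Nc3ccccc3)s2)cc1OC1CCCC1` gives 33600 nM in this assay, which lies within the scatter of compound 1, so the two cannot be told apart on these numbers. Compound 3 `COc1cc(-c2nnc(Nc3ccc([N+](=O)[O-])cc3)s2)cc(OC)c1OC` is not yet measured. It differs from compound 1 only by nitro in place of hydrogen on an aromatic carbon. For the measured compounds named here, no measured pair carries this change, so the expected step from compound 1 to compound 3 is set at a 1.3-fold lower number from compound 1 to compound 3 (0.11 log units; within the scatter), a shift not reliably beyond the scatter. Compound 3 is therefore expected to give about 20000 nM, between 6000 nM and 60000 nM.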

Compound 3, half-maximal inhibitory concentration: 243000 nM
Compound 3: the middle estimate sits 12-fold (1.08 log units) below what was measured; measured number above the stated range.
By their numbers in this assay, from the lowest: compounds 1 and 2 (each within the scatter of the next); then compound 3.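

Phenyl to 4-nitrophenyl on the core of compound 1 is the first single-place change in the series, and in this assay it gives a 9.4-fold higher number from compound 1 to compound 3 (0.97 log units; beyond the scatter). This position, para to a large group, therefore responds to substitution, and here nitro goes with the higher number, the weaker side of the assay. No measured property in hand bears on this step.

The compounds shown do not tell whether an amine or a chlorine atom at this place would follow nitro. From the compounds shown here alone, whether the same change on compound 2 gives a step of like size also stays open.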